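Swapping the amide substituent: oxetanyl to pyrimidinyl

This account rests on a few compounds, and the source may have more. Where it says the series, first, only, none or still open, it means among the compounds named here.

Measured compounds:
Compound 1, `CCc1ccc(OCC(=O)N(CC)Cc2cccs2)cc1`, gives 67 nM.
Compound 2, `CCN(Cc1cccs1)C(=O)c1cc2cc(C)ccc2[nH]1`, gives 2010 nM.
Compound 3, `Cc1ccc(OCC(=O)N(Cc2cccs2)C2COC2)cc1`, gives 23000 nM.

All three were tested in an assay on HEK293 cells for agonist activity at transient receptor potential cation channel subfamily M member 8 (Homo sapiens), read by fluorescence and calcium flux, with a stated time of 15 min; on this read-out higher numbers stand for an effect only at larger amounts of compound and lower numbers for an effect already at smaller amounts. Among them, compound 3 stands at the highest number: compound 2 sits well below it, and compound 1 sits far below it, both gaps lying beyond the usual scatter of this test. Compound 3 is therefore the weakest agonist of the three in this assay.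

The next compound, compound 4, `Cc1ccc(OCC(=O)N(Cc2cccs2)c2ncccn2)cc1`, has not yet been measured. It keeps the shared core of compound 3 and changes one substituent: pyrimidin-2-yl in place of oxetan-3-yl on an amide-type nitrogen. Going by the values given here, no pair of measured compounds differs by exactly this change, so the size of the step must be guessed from the surrounding numbers alone. Compound 1, carrying a small saturated group on the same amide-type nitrogen, gives 67 nM, which shows that this position tolerates variation, while compound 3 with the oxetan-3-yl group gives 23000 nM. With a six-membered aromatic ring in place of the four-membered one, a moderate move toward a lower number is expected, with the step of a 2.9-fold lower number from compound 3 to compound 4 (0.46 log units; beyond the scatter). The estimated value for compound 4 in this assay is 8000 nM, with a plausible range from 1500 nM to 40000 nM.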

Compound 4, half-maximal effective concentration: 3700 nM
The estimate for compound 4 lay 2.2-fold (0.33 log units) above the measured number; the measured number falls inside the stated range.
By their numbers in this assay, from the lowest: compound 1; then compounds 2 and 4 (each within the scatter of the next); then compound 3.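

In this assay, going by these compounds alone, a 6.2-fold lower number from compound 3 to compound 4 (0.79 log units; beyond the scatter), the first step in this set that comes from a change in one place alone. It shows that the group on this amide-type nitrogen can, on its own, move the number beyond the usual scatter, although the move is modest and compound 4 remains a weak agonist on this read-out. The step swaps a four-membered non-aromatic ring with one hetero atom for a six-membered aromatic ring with two hetero atoms, and no other measurement here bears on which of these differences produced the shift.

On these data alone, this single pair cannot separate ring size, aromatic character and the number of ring nitrogens, so it remains open whether a plain phenyl ring or a saturated six-membered ring such as tetrahydropyran-4-yl would give a similar number on the same nitrogen. Also open, as far as these compounds go, is how an open chain such as propyl, or a ring carrying a basic amine, would behave at this position with the rest of compound 4 left unchanged.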